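Configuration at one ring carbon: compound 3 to compound 4

A few compounds are considered here, and "the series" means these few. Any claim that something is new, unique, unknown or untested is made for them only; others in the source may bear on it.

Values in a functional assay on SGC-7901 cells (Homo sapiens) for antiproliferative activity, in the presence of a further agent that is not named here (a lower number here means a stronger inhibitor, a higher number a weaker inhibitor), so far:
- compound 1 `NCCN[C@@H]1CC[C@H](c2ccc(Cl)c(Cl)c2)c2ccccc21` gives 10700 nM
- compound 2 `NCCCCN[C@@H]1CC[C@H](c2ccc(Cl)c(Cl)c2)c2ccccc21` gives 6300 nM
- compound 3 `NCCCCCCN[C@@H]1CC[C@@H](c2ccc(Cl)c(Cl)c2)c2ccccc21` gives 11100 nM

Compound 3 at 11100 nM lies within the scatter of both other values, so none of the three stands apart. Compound 4 `NCCCCCCN[C@@H]1CC[C@H](c2ccc(Cl)c(Cl)c2)c2ccccc21` is still unmeasured. The change to it is the two compounds have the same atoms and bonds and differ only in configuration as drawn: 1 of 2 stereo elements differ; a stereocentre at a saturated ring carbon is drawn S in compound 3 and R in compound 4 and no group enters or leaves. Going by the values given here, no measured pair tests this change directly. Among the compounds with values here, the one measured step, a 1.7-fold lower number from compound 1 to compound 2 (0.23 log units; within the scatter) in size, lies within the scatter and concerns the chain, not the stereocentre. Compound 1 at 10700 nM and compound 2 at 6300 nM are drawn with the configuration of compound 4 at that ring carbon, and neither value separates from compound 3 at 11100 nM on the numbers. No step beyond the scatter is therefore expected in this assay, and the estimated change is a 1.5-fold lower number from compound 3 to compound 4 (0.17 log units; within the scatter) at most within it. For compound 4 the estimated value is 7500 nM with an expected range of 3500 nM to 16000 nM for a single measurement.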

Compound 4, half-maximal inhibitory concentration: 18900 nM
Estimate against measurement, compound 4: 2.5-fold (0.40 log units) below; measured number above the stated range.
By their numbers in this assay, from the lowest: compounds 2, 1, 3 and 4 (each within the scatter of the next, the first and the last beyond it).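

The pair reads this ring carbon alone: the fact that compounds 3 and 4 differ only in the configuration as drawn. In this assay the direct test gives a 1.7-fold higher number from compound 3 to compound 4 (0.23 log units; within the scatter), so on these numbers the configuration at this carbon does not separate the two forms. Going by these compounds alone, with that carbon drawn alike, the chain comparisons give a 3.0-fold higher number from compound 2 to compound 4 (0.48 log units; beyond the scatter), the one step here beyond the scatter, and a 1.8-fold higher number from compound 1 to compound 4 (0.25 log units; within the scatter), which stays within it, so the only readable difference in these new steps lies in the chain and not in the stereocentre.

As far as these compounds go, whether the same inversion would read differently on the shorter chains of compound 1 and compound 2 stays open, as does the effect of inverting the second stereocentre, drawn alike in all four compounds. A longer chain, or a carboxylic acid in place of the chain's amine, also lies outside the compounds shown.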